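Amino in Place of Chloro: What Compound 3 May Show

The compounds below may be only part of what the source reports. "The series", "measured", "known", "first", "only" and "open" are said of these compounds alone.

Compound 1 `C(=C/c1ncnc2c1ncn2Cc1ccccc1)\c1ccccc1` gives 93% in a functional assay on K562 cells (Homo sapiens) for inhibition, read by thymidine incorporation, with a stated time of 48 h, tested at 10 ug/mL; a lower number here means less inhibition, a higher number more inhibition at the concentration tested (going by the name of the read-out).
Compound 2 `Clc1nc(/C=C/c2ccccc2)c2ncn(Cc3ccccc3)c2n1` gives 99% in this assay.

Compound 2 stands highest of the two numbers, with compound 1 nearest; the step of a number 6 percentage points higher from compound 1 to compound 2 (within the scatter) came from chloro in place of hydrogen on an aromatic carbon. Compound 3 `Nc1nc(/C=C/c2ccccc2)c2ncn(Cc3ccccc3)c2n1` differs from compound 2 by amino in place of chloro on an aromatic carbon. Going by the values given here, no measured step covers an amino group entering, so the expectation rests on compound 2 alone and on the small size of a number 6 percentage points higher from compound 1 to compound 2 (within the scatter). Compound 3 is therefore expected to give about 90% in this assay, with a range of 72% to 100%. The estimated step is a number 9 percentage points lower from compound 2 to compound 3 (within the scatter), none beyond the scatter.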

Compound 3, a percentage reported as inhibition, at one concentration (the size of the read-out at that concentration, not a potency): 91%
For compound 3 the middle estimate is 1 percentage points below the measured one; low and high end bracket the measured number.
By their numbers in this assay, from the lowest: compounds 3, 1 and 2 (each within the scatter of the next).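

At this place between two ring nitrogen atoms, amino in place of chloro gives a number 8 percentage points lower from compound 2 to compound 3 (within the scatter) in this assay and amino in place of hydrogen gives a number 2 percentage points lower from compound 1 to compound 3 (within the scatter) in the same read-out. Hydrogen, chloro and amino therefore cannot be told apart here, although amino is the only one of the three that brings a hydrogen-bond donor. Nothing available explains this result.

Going by these compounds, whether a methylamino group, a hydroxyl or a longer chain at this place would also stay within the scatter remains open. A reading at one concentration also leaves any difference in potency among these compounds open.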